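The source may report more compounds than this note shows. Statements on the series, on what has been measured and on what is new or still open speak of the compounds shown alone.

Three esters of the shared core have been run in a functional assay on MCF7 cells (Homo sapiens) for antiproliferative activity, read by sulforhodamine B assay, with a stated time of 48 h, tested at 50 uM; on this read-out higher numbers stand for more inhibition at the one concentration tested (going by the name of the read-out) and lower numbers for less inhibition. Compound 1 `COc1cccc(C(=O)Oc2cc3c(cc2C)[C@@H](C(C)C)CC=C3C)c1` gives 11.9% and compound 2 `CC1=CC[C@H](C(C)C)c2cc(C)c(OC(=O)c3cccc(C)c3)cc21` gives 54.9%. Compound 3 `CC1=CC[C@H](C(C)C)c2cc(C)c(OC(=O)c3cccc([N+](=O)[O-])c3)cc21` gives 29.3%, the second highest of the three numbers, with a number 17.4 percentage points higher from compound 1 to compound 3 (beyond the scatter) and a number 25.6 percentage points lower from compound 2 to compound 3 (beyond the scatter) placing it between the other two. Compound 4 `CC1=CC[C@H](C(C)C)c2cc(C)c(OC(=O)Nc3ccccc3)cc21` differs from compound 3 by anilino in place of 3-nitrophenyl on a carbonyl carbon. Going by the values given here, no measured step matches this change: every measured step alters only the substituent on the aromatic ring, and a number 43 percentage points higher from compound 1 to compound 2 (beyond the scatter) shows how far that alone can move the read-out. With the ring substituent gone and the linkage changed, the expectation is broad. In this assay compound 4 is expected near 25% (range 5% to 55%). That estimate means an expected step of a number 4.3 percentage points lower from compound 3 to compound 4 (within the scatter).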

Compound 4, a percentage reported as inhibition, at one concentration (the size of the read-out at that concentration, not a potency): 75.1%
Compound 4: the middle estimate sits 50.1 percentage points below what was measured; the whole stated range lies below it.
By their numbers in this assay, from the lowest: compound 1; then compound 3; then compound 2; then compound 4.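

In this assay, the anilino group on the carbonyl carbon stands above all three esters, with a number 63.2 percentage points higher from compound 1 to compound 4 (beyond the scatter) and a number 45.8 percentage points higher from compound 3 to compound 4 (beyond the scatter) and a number 20.2 percentage points higher from compound 2 to compound 4 (beyond the scatter) as the steps. Changing the group on the carbonyl carbon therefore moves the read-out beyond the range spanned by the three aromatic substituents, and it brings in a hydrogen-bond donor. Nothing available accounts for this rise.

Open: whether methyl, methoxy or nitro on the anilino ring follows the ester order, and whether a cyclohexylamino group on the carbonyl carbon retains the high number.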